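The source may hold more compounds than are shown below. What is called first, only, known or untested is meant among the compounds shown, and "the series" means these compounds.

Measured compounds:
- compound 1 `CCCCc1cn(C[C@H](O)[C@H]2OC(=O)C(OCc3ccccc3)=C2OCc2ccccc2)nn1`: 47500 nM
- compound 2 `CCCCCc1ccc(-c2cn(C[C@H](O)[C@H]3OC(=O)C(OCc4ccccc4)=C3OCc3ccccc3)nn2)cc1`: 12200 nM

Series notes. In a functional assay on SW-620 cells (Homo sapiens) for antiproliferative activity, read by MTT assay, with a stated time of 72 h (a higher number here means a weaker inhibitor, a lower number a stronger inhibitor), compound 1 gives 47500 nM. In this assay, among the measured compounds shown here, compound 2 gives 12200 nM, the lowest of the two numbers so far; the only neighbour is compound 1, and the step of a 3.9-fold lower number from compound 1 to compound 2 (0.59 log units; beyond the scatter) is beyond the scatter, so compound 2 stands as the stronger inhibitor of the pair.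

Compound 3 `O=C1O[C@H]([C@@H](O)Cn2cc(CNS(=O)(=O)c3ccc(F)cc3)nn2)C(OCc2ccccc2)=C1OCc1ccccc1` is not yet measured. It differs from compound 2 in one place: (((4-fluorophenyl)sulfonyl)amino)methyl in place of 4-pentylphenyl on an aromatic carbon.

For the measured compounds named here, only one measured step bears on this change, and only indirectly. The step of a 3.9-fold lower number from compound 1 to compound 2 (0.59 log units; beyond the scatter) shows that placing 4-pentylphenyl on that aromatic carbon lowered the number modestly relative to butyl. Compound 3 removes the 4-pentylphenyl again but puts in its place a group of similar size that also carries one six-membered aromatic ring, so the number is not expected to return fully toward compound 1. Nothing measured tells how the sulfonyl and the donor count of the entering group matter here. Taken together, for compound 3 the expected step of a 1.6-fold higher number from compound 2 to compound 3 (0.21 log units; within the scatter) is a small rise, within or near the scatter, so compound 3 is estimated at 20000 nM in this assay, with a plausible range from 6000 nM to 65000 nM.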

Compound 3, half-maximal inhibitory concentration: 41100 nM
The estimate for compound 3 lay 2.1-fold (0.31 log units) below the measured number; the measured number falls inside the stated range.
By their numbers in this assay, from the lowest: compound 2; then compounds 3 and 1 (each within the scatter of the next).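

In this assay the aromatic carbon of the five-membered aromatic ring with 3 nitrogen proves sensitive to more than the presence of a six-membered aromatic ring: 4-pentylphenyl and (((4-fluorophenyl)sulfonyl)amino)methyl each carry one such ring of carbon only, yet the exchange gives a 3.4-fold higher number from compound 2 to compound 3 (0.53 log units; beyond the scatter) and removes the advantage seen with 4-pentylphenyl. The comparison with the butyl compound gives a 1.2-fold lower number from compound 1 to compound 3 (0.06 log units; within the scatter) and therefore shows no separation between butyl and the larger entering group, so size and an aromatic ring alone do not account for the number of compound 2 in this pair of changes. No measurement on hand explains why the two ring-bearing groups differ.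

The change from compound 2 to compound 3 alters the ring's attachment, the sulfonyl, the amino hydrogen, the fluorine and the pentyl chain together, so their separate contributions remain unresolved. A plain phenyl on the same aromatic carbon would test whether the pentyl chain is needed, while a benzyl group or a carboxamide in place of the sulfonyl would help separate the linker's contribution from that of the ring.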